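This account rests on a few compounds, and the source may have more. Where it says the series, first, only, none or still open, it means among the compounds named here.

Measured compounds:
Compound 1 `Oc1cccc(-c2cc(-c3ccsc3)cc(-c3cccc(O)c3)n2)c1` gives 4.5% in an assay on isolated protein for inhibition of DNA topoisomerase 1 (Homo sapiens), with a stated time of 30 min, tested at 20 uM; on this read-out higher numbers stand for a stronger effect at the one concentration tested and lower numbers for a weaker effect.
Compound 2 `Oc1cccc(-c2cc(-c3ccco3)cc(-c3cccc(O)c3)n2)c1` gives 0% in this assay.
Compound 3 `Oc1cccc(-c2cc(-c3ccoc3)cc(-c3ccccc3O)n2)c1` gives "not determined" (no result reported) in this assay, that is, no result.

Compound 3 therefore stands nowhere on the numbers shown: there is no single figure for it in this assay. Compound 4 `Oc1cccc(-c2cc(-c3ccoc3)cc(-c3cccc(O)c3)n2)c1` differs from compound 3 in one place: 3-hydroxyphenyl in place of 2-hydroxyphenyl on an aromatic carbon. Among the compounds with values here, none of the measured steps covers this exchange of one hydroxyphenyl group for another. Within the data shown here, the only measured step, a number 4.5 percentage points lower from compound 1 to compound 2 (within the scatter), concerns a different position and is within the scatter, so it gives no guide to the direction of the present change. What the numbers do show is that compound 1 and compound 2, which carry the same two 3-hydroxyphenyl groups as compound 4 and differ from it only in having thiophen-3-yl or furan-2-yl where compound 4 has furan-3-yl, both give low values in this assay. On that basis no step beyond the scatter is expected for compound 4. Compound 4 is expected to give a low value, estimated at 3% with a range from 0% to 15%.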

Compound 4, a percentage reported as inhibition, at one concentration (the size of the read-out at that concentration, not a potency): 2%
Estimate against measurement, compound 4: 1 percentage points above, and the stated range covers the measured number.
By their numbers in this assay, from the lowest: compounds 2, 4 and 1 (each within the scatter of the next).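

In this assay, furan-3-yl in place of furan-2-yl gives a number 2 percentage points higher from compound 2 to compound 4 (within the scatter) and furan-3-yl in place of thiophen-3-yl gives a number 2.5 percentage points lower from compound 1 to compound 4 (within the scatter), so these three rings cannot be told apart at this place on the shared core when both 3-hydroxyphenyl groups are present. The exchange of 2-hydroxyphenyl for 3-hydroxyphenyl cannot be read, as compound 3 has no result to compare with compound 4. No measurement shown offers a cause for these values.

As far as these compounds go, with only these three rings compared, it remains open whether a different kind of group in place of furan-3-yl, such as an amine or a carboxylic acid, would change the read-out beyond the scatter. From the compounds shown here alone, it also remains open what 4-hydroxyphenyl would give in place of 3-hydroxyphenyl.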